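Notes on the indole halogen swap, compound 2 to compound 4

This account rests on a few compounds, and the source may have more. Where it says the series, first, only, none or still open, it means among the compounds named here.

Measured so far in a functional assay on LNCaP cells (Homo sapiens) for cytotoxicity, read by MTT assay, with a stated time of 48 h, in the absence of a further agent; a lower number here means a stronger inhibitor, a higher number a weaker inhibitor:
compound 1 `COc1ccc2[nH]cc(-c3nc(C(=O)Nc4cc(OC)c(OC)c(OC)c4)cs3)c2c1` gives > 100000 nM
compound 2 `COc1cc(NC(=O)c2csc(-c3c[nH]c4ccc(Br)cc34)n2)cc(OC)c1OC` gives > 100000 nM
compound 3 `COc1ccc(NC(=O)c2csc(-c3c[nH]c4ccc(F)cc34)n2)cc1` gives 66400 nM

Compound 2 stands at the edge of what this assay reports: its value > 100000 nM is a limit of the assay, not a number. Compound 1 also sits at a limit in this assay, > 100000 nM. Compound 3 is the only one of the three with a measured number, 66400 nM in this assay. Among the compounds with values here, the one measured step, a step that the two limits leave unreadable from compound 1 to compound 2, cannot be read for size, since both ends rest at the limit of > 100000 nM in this assay, at which 2 of the 3 values shown sit.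

Compound 4 `COc1cc(NC(=O)c2csc(-c3c[nH]c4ccc(F)cc34)n2)cc(OC)c1OC` differs from compound 2 by fluoro in place of bromo on an aromatic carbon. Within the data shown here, no measured step covers this particular change, and the one step that exists is unreadable. Compound 3 carries the same fluoro group on the indole with a different amide part and does return a number in this assay, 66400 nM, so a value rather than a limit is possible for compound 4, though weak activity remains the likelier outcome.

Compound 4 is therefore estimated at 100000 nM in this assay, with a range of 40000 nM to 250000 nM. The step this estimate implies, a number no higher from compound 2 to compound 4 (the limit leaves the size open), is expected to be small and may again end at a limit.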

Compound 4, half-maximal inhibitory concentration: > 100000 nM
Compound 4: a limit, no number; the forecaster's own chance of this, stated with the estimate: 55%; the middle value sits exactly at the limit.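

The steps linking compound 4 to compound 1 and to compound 2 cannot be read for size, because each of these compounds rests at a limit and not at a number: the limit of > 100000 nM in this assay, at which 3 of the 4 values shown sit.

Left open is whether the change from 5-bromo-1H-indol-3-yl to 5-fluoro-1H-indol-3-yl shifts the read-out in this assay at all, with neither side of it carrying a number.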